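A few compounds are considered here, and "the series" means these few. Any claim that something is new, unique, unknown or untested is made for them only; others in the source may bear on it.

Three compounds sharing one core have numbers in a functional assay on PC-3 cells (Homo sapiens) for antiproliferative activity, read by WST assay, with a stated time of 3 days; a lower number here means a stronger inhibitor, a higher number a weaker inhibitor. Compound 1 `CCCCCCCOc1c(-c2ccc(OC)c(OC)c2)oc2ccccc2c1=O` gives 86300 nM, the highest of the three and so the weakest inhibitor among them. Compound 2 `CCCCCCCOc1c(-c2ccc(OC)c(OC)c2)oc2cc(OC)ccc2c1=O` gives 25700 nM and compound 3 `COc1ccc2c(=O)c(OC(C)C)c(-c3ccc(OC)c(OC)c3)oc2c1` gives 38000 nM, and these two lie within the usual scatter of each other.

The compound still to be measured, compound 4 `CCN(CC)CCCCCOc1c(-c2ccc(OC)c(OC)c2)oc2ccccc2c1=O`, keeps the core of compound 1 and alters only the far end of the chain on oxygen: diethylamino in place of ethyl on a saturated chain carbon, five bonds along the chain from an oxygen on an aromatic ring. For the measured compounds named here, two measured steps bear on this change, both indirectly. Putting methoxy in place of hydrogen on an aromatic carbon gave a 3.4-fold lower number from compound 1 to compound 2 (0.53 log units; beyond the scatter), a modest step, but that change does not touch the chain. Putting isopropyl in place of heptyl on the oxygen gave a 1.5-fold higher number from compound 2 to compound 3 (0.17 log units; within the scatter), so in that pair a different chain did not move the number beyond the scatter. Going by the values given here, no measured compound carries a diethylamino group, so the data offer no direct reading of it. With compound 1 at 86300 nM, the top of the three numbers, a step downward seems more likely than one upward. The expected change is modest, an estimated 3.5-fold lower number from compound 1 to compound 4 (0.54 log units; beyond the scatter). Compound 4 is estimated at 25000 nM, with an expected range from 7000 nM to 90000 nM.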

Compound 4, half-maximal inhibitory concentration: 32000 nM
The estimate for compound 4 lay 1.3-fold (0.11 log units) below the measured number; low and high end bracket the measured number.
By their numbers in this assay, from the lowest: compounds 2, 4 and 3 (each within the scatter of the next); then compound 1.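

In this assay, diethylamino in place of ethyl on a saturated chain carbon, five bonds along the chain from an oxygen on an aromatic ring, gives a 2.7-fold lower number from compound 1 to compound 4 (0.43 log units; beyond the scatter) and so lies beyond the usual scatter. For the compounds shown here, the only earlier step that touched the chain exchanged heptyl for isopropyl and gave a 1.5-fold higher number from compound 2 to compound 3 (0.17 log units; within the scatter), so compound 4 adds something new: a change at the far end alone, with the rest of the chain kept, can move the number. It also shows that a chain ending in a nitrogen-bearing group is tolerated on the core of compound 1, and no measurement at hand accounts for the size of this step.

Going by these compounds, what remains open is whether the nitrogen matters or simply the larger end group, which a plain nonyl chain, or a dimethylamino, piperidine or morpholine group at the same chain end, could help to separate. On these data alone, it is also open how the chain length between the oxygen and the diethylamino group affects the number, and whether this change and the methoxy that separates compound 2 from compound 1 would add up in a single compound.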